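Swapping one halogenated phenyl for another on a shared core

This account rests on a few compounds, and the source may have more. Where it says the series, first, only, none or still open, it means among the compounds named here.

Of the compounds shown here, two have been measured in a functional assay on K562 cells (Homo sapiens) for cytotoxicity, read by CCK-8 assay, with a stated time of 72 h; a higher number here means a weaker inhibitor, a lower number a stronger inhibitor. Compound 1, with the structure `C=CCn1c(=O)/c(=C\c2cccc(Cl)c2)[nH]c(=O)/c1=C\c1ccccc1OC`, gives 2700 nM in this assay. Compound 2, with the structure `COc1ccccc1/C=c1/[nH]c(=O)/c(=C\c2nc[nH]c2C(C)(C)C)[nH]c1=O`, gives 60 nM in this assay. Compound 1 thus stands at the higher of the two numbers, and its gap to compound 2 is beyond the scatter, so compound 1 is the weaker inhibitor of the two; compound 2 differs from it in more than one place, so no single change can be credited for that gap.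

Compound 3, with the structure `C=CCn1c(=O)/c(=C\c2ccccc2F)[nH]c(=O)/c1=C\c1ccccc1OC`, has not yet been measured. It differs from compound 1 in one place: 2-fluorophenyl in place of 3-chlorophenyl on a double-bonded chain carbon bound to an aromatic carbon. Among the compounds with values here, no measured pair shows a step of this kind, so the size of the change is open. Since the group that leaves and the group that enters are alike in count and in character, the step from compound 1 to compound 3 is expected to be small, at most within or near the scatter, with no clear direction: a 1.2-fold higher number from compound 1 to compound 3 (0.07 log units; within the scatter). Compound 3 is therefore expected to give about 3200 nM in this assay, with a range from 1100 nM to 9500 nM.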

Compound 3, half-maximal inhibitory concentration: 5600 nM
Estimate against measurement, compound 3: 1.8-fold (0.24 log units) below, and the stated range covers the measured number.
By their numbers in this assay, from the lowest: compound 2; then compound 1; then compound 3.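

In this assay, this position now has its first measured step: 2-fluorophenyl in place of 3-chlorophenyl, on a double-bonded chain carbon bound to an aromatic carbon, gives a 2.1-fold higher number from compound 1 to compound 3 (0.32 log units; beyond the scatter). The step is modest, but it shows that the number can move at this position even when the group that leaves and the group that enters match in heavy-atom count and in ring type, and neither has hydrogen-bond donors or acceptors. The swap changes both the halogen and its place on the phenyl ring, so this single step cannot separate the two changes, and no measurement at hand explains the shift.

The compounds shown leave open whether the identity of the halogen or its place on the ring matters more, a question that 2-chlorophenyl or 3-fluorophenyl at this position could help to settle. They also leave open how far the number would move with a group of another kind here, such as an unsubstituted phenyl or a phenyl carrying an amine.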